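This account rests on a few compounds, and the source may have more. Where it says the series, first, only, none or still open, it means among the compounds named here.

Compound 1 `COc1cccc(/C=C2\SC(=O)N(Cc3ccc(C(=O)O)cc3)C2=O)c1`: 48000 nM
Compound 2 `O=C(O)c1ccc(CN2C(=O)S/C(=C\c3ccccc3)C2=O)cc1`: 72000 nM
Compound 3 `Cn1cccc1/C=C1\SC(=O)N(Cc2ccc(C(=O)O)cc2)C1=O`: 90000 nM

These three share one core and differ only in the group on the double-bonded chain carbon. In a functional assay on HeLa cells (Homo sapiens) for cytotoxicity, read by MTT assay, with a stated time of 24 h (a lower number here means a stronger inhibitor, a higher number a weaker inhibitor), compound 3 gives the highest number of the three, yet neither a 1.9-fold higher number from compound 1 to compound 3 (0.27 log units; within the scatter) nor a 1.3-fold higher number from compound 2 to compound 3 (0.10 log units; within the scatter) exceeds the scatter, so no real order separates them. Compound 4 `O=C(O)c1ccc(CN2C(=O)S/C(=C\c3ccco3)C2=O)cc1` keeps the same core and differs from compound 3 by furan-2-yl in place of 1-methyl-1H-pyrrol-2-yl on a double-bonded chain carbon bound to a double-bonded ring carbon. The swaps already seen at this position, together with a 1.5-fold higher number from compound 1 to compound 2 (0.18 log units; within the scatter), all stayed within the scatter, so no step beyond the scatter is expected here; the expected step is a 1.1-fold lower number from compound 3 to compound 4 (0.05 log units; within the scatter). Compound 4 is therefore estimated at 80000 nM, with a range from 35000 nM to 180000 nM.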

Compound 4, half-maximal inhibitory concentration: 80000 nM
The estimate for compound 4 equals the measured number at the digits printed; measured number inside the range.
By their numbers in this assay, from the lowest: compounds 1, 2, 4 and 3 (each within the scatter of the next).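

Furan-2-yl, the first group here with an oxygen in its ring, changes nothing that can be told apart from the earlier compounds in this assay: a 1.1-fold lower number from compound 3 to compound 4 (0.05 log units; within the scatter), a 1.1-fold higher number from compound 2 to compound 4 (0.05 log units; within the scatter) and a 1.7-fold higher number from compound 1 to compound 4 (0.22 log units; within the scatter) all stay within the scatter. Across these four compounds, then, neither six-membered nor five-membered aromatic rings at this place give values that can be separated. No evidence at hand bears on this result. The compounds shown leave open whether a group without an aromatic ring at this place, such as a cyclohexyl group, an amine or a longer alkyl chain, would give a step beyond the scatter.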